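The source may hold more compounds than are shown below. What is called first, only, known or untested is meant among the compounds shown, and "the series" means these compounds.

Of the compounds shown here, three have been tested in a functional assay on DU-145 cells (Homo sapiens) for cytotoxicity, read by XTT assay, with a stated time of 72 h; on this read-out lower numbers stand for stronger inhibition and higher numbers for weaker inhibition. Compound 1, `ClCc1c[se]c(N/N=C/c2csc(-c3ccccc3)n2)n1`, gives 16400 nM in this assay. Compound 2, `Cc1c[se]c(NNC(=O)c2ccccc2)n1`, does not reach a number: in this assay compound 2 reads > 89200 nM, which is a limit of the assay. Compound 3, `O=C(NNc1nc(-c2ccccc2)c[se]1)c1ccccc1`, likewise stops at a limit, and in this assay compound 3 reads > 73000 nM. Compound 3 therefore stands only at a limit, and of the three values shown one further value is also a limit rather than a number. The step that the two limits leave unreadable from compound 2 to compound 3 puts phenyl in place of methyl on an aromatic carbon, but both of its ends sit at limits, the limit of > 73000 nM in this assay, at which 1 of the 3 values shown sits, and (the limit of > 89200 nM in this assay, at which 1 of the 3 values shown sits), so its size cannot be read.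

Compound 4, `O=C(NNc1nc(-c2ccccc2)c[se]1)c1ccc(Cl)cc1`, differs from compound 3 by chloro in place of hydrogen on an aromatic carbon. Going by the values given here, no measured step involves a chloro group, and the only measured step is unreadable, so nothing in the data points to a change beyond the usual scatter in this assay. The expectation for compound 4 is 80000 nM, with a range from 30000 nM to 200000 nM, and most likely it will again be reported as a limit. The step that the limit leaves unreadable from compound 3 to compound 4 is what this estimate means.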

Compound 4, half-maximal inhibitory concentration: 65100 nM
Beside the measured number, compound 4's estimate is 1.2-fold (0.09 log units) above it; the range from low to high includes it.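

Compound 3 stops at a limit of the assay, reading > 73000 nM in this assay, so it gave no number to measure a change against. Going by these compounds alone, putting chloro in place of hydrogen on an aromatic carbon, para to a large group, turns phenyl into 4-chlorophenyl and gives the first step here with a real number at one end: an at least 1.1-fold lower number from compound 3 to compound 4 (0.04 log units; that floor lies within the scatter). That floor does not establish a change, and the true size of the step stays unknown because one of its ends is only a limit: the limit of > 73000 nM in this assay, at which 1 of the 4 values shown sits.

Whether this position on the six-membered ring responds to substitution at all remains open, as chloro is the only group shown there; a methoxy group, an amine or a carboxylic acid in the same place could show whether the number moves beyond the usual scatter. Also open, on these data alone, is whether chloro at this position would have any comparable effect on compound 2, which carries methyl where compound 3 carries phenyl.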